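Series notes: moving from 4-bromophenyl to 3-(trifluoromethyl)phenyl

The source may hold more compounds than are shown below. What is called first, only, known or untested is meant among the compounds shown, and "the series" means these compounds.

The shared core is that of compound 1 `OC[C@H]1O[C@@H](n2cnc3c(SCc4ccccc4Cl)ncnc32)[C@H](O)[C@@H]1O`, which in an assay on isolated protein for inhibition of Equilibrative nucleoside transporter 1 (Homo sapiens) (a lower number here means a stronger inhibitor, a higher number a weaker inhibitor), gives 117 nM. Compound 2 `OC[C@H]1O[C@@H](n2cnc3c(SCc4ccccc4Br)ncnc32)[C@H](O)[C@@H]1O` carries bromo in place of chloro on an aromatic carbon and gives 151 nM in this assay; the step is a 1.3-fold higher number from compound 1 to compound 2 (0.11 log units; within the scatter). Compound 3 `OC[C@H]1O[C@@H](n2cnc3c(SCc4ccc(Br)cc4)ncnc32)[C@H](O)[C@@H]1O` has 4-bromophenyl in place of 2-chlorophenyl on a saturated chain carbon bound to a sulfur and gives 11.5 nM in this assay. Compound 3 stands lowest of the three numbers: a 10-fold lower number from compound 1 to compound 3 (1.01 log units; beyond the scatter) and a 13-fold lower number from compound 2 to compound 3 (1.12 log units; beyond the scatter).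

Compound 4 `OC[C@H]1O[C@@H](n2cnc3c(SCc4cccc(C(F)(F)F)c4)ncnc32)[C@H](O)[C@@H]1O` is not yet measured. Its difference from compound 3 is 3-(trifluoromethyl)phenyl in place of 4-bromophenyl on a saturated chain carbon bound to a sulfur. Among the measured compounds shown here, the steps that bear on it are the two that replaced 2-chlorophenyl or 2-bromophenyl with 4-bromophenyl, both large and both toward lower numbers. Nothing measured covers 3-(trifluoromethyl)phenyl or a trifluoromethyl group, so the direction of this change is unresolved; the two large steps show that where the substituent sits on the phenyl matters strongly in this assay, while the small step from compound 1 to compound 2 shows that the halogen identity mattered little. A number between compound 3 and compounds 1 and 2 is therefore expected, with wide uncertainty. For compound 4 the estimate in this assay is 40 nM, range 10 nM to 160 nM, which is expected to be a 3.5-fold higher number from compound 3 to compound 4 (0.54 log units; beyond the scatter).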

Compound 4, inhibition constant: 19.1 nM
Compound 4: middle estimate off by 2.1-fold (0.32 log units), on the high side; the range from low to high includes it.
By their numbers in this assay, from the lowest: compounds 3 and 4 (each within the scatter of the next); then compounds 1 and 2 (each within the scatter of the next).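

In this assay, the step reads a 1.7-fold higher number from compound 3 to compound 4 (0.22 log units; within the scatter), so 3-(trifluoromethyl)phenyl and 4-bromophenyl cannot be told apart on a saturated chain carbon bound to a sulfur, even though the entering group has more heavy atoms and no bromine. The low numbers are therefore not tied to 4-bromophenyl: the steps of a 7.9-fold lower number from compound 2 to compound 4 (0.90 log units; beyond the scatter) and a 6.1-fold lower number from compound 1 to compound 4 (0.79 log units; beyond the scatter) both lie beyond the scatter, leaving 2-bromophenyl and 2-chlorophenyl as the two groups at the higher numbers among these four compounds, with none going against that split. No measurement available here accounts for this result.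

The change from compound 3 to compound 4 alters both the substituent and its place on the phenyl, so the compounds shown do not separate those two contributions. Also open, going by these compounds, is how this position responds to an unsubstituted phenyl, to an amine or a carboxylic acid on the phenyl, or to a longer chain on the sulfur, since all four compounds carry a halogen-bearing or fluorine-bearing phenyl on the same saturated carbon.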